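Biaryl amines on the shared core: a side-chain swap

The compounds below may be only part of what the source reports. "The series", "measured", "known", "first", "only" and "open" are said of these compounds alone.

Measured so far:
compound 1 `O=C1C(Nc2ccc(-c3ccc(Cl)cc3)cc2)=CC(=O)c2ncncc21` — 9700 nM
compound 2 `O=C1C(Nc2cccc(-c3ccccc3)c2)=CC(=O)c2ncncc21` — 2400 nM

Both compounds were run in a functional assay on MIA PaCa-2 cells (Homo sapiens) for cytotoxicity, read by MTT assay, with a stated time of 72 h; on this read-out higher numbers stand for weaker inhibition and lower numbers for stronger inhibition. Compound 1 gives 9700 nM, the higher of the two numbers, and compound 2 gives 2400 nM, which lies beyond the scatter from compound 1. Among the compounds with values here, no step between measured compounds is recorded, so nothing here isolates the effect of a single change.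

Compound 3 `CCc1ccc(-c2ccc(NC3=CC(=O)c4ncncc4C3=O)cc2)cc1` is not yet measured in this assay. It differs from compound 1 by ethyl in place of chloro on an aromatic carbon. Within the data shown here, no measured pair mirrors this exchange, and compound 2 differs from compound 1 elsewhere in the molecule, so no direction can be drawn from the numbers in hand. The step from compound 1 to compound 3 is therefore expected to be small, around a 1.2-fold lower number from compound 1 to compound 3 (0.08 log units; within the scatter), with no clear direction beyond the scatter. Compound 3 is estimated at 8000 nM, within the range 3000 nM to 25000 nM.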

Compound 3, half-maximal inhibitory concentration: 1500 nM
Estimate against measurement, compound 3: 5.3-fold (0.73 log units) above, outside the stated range (below it).
By their numbers in this assay, from the lowest: compounds 3 and 2 (each within the scatter of the next); then compound 1.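

In this assay, within the data shown here, ethyl in place of chloro on an aromatic carbon, para to a large group, gives a 6.5-fold lower number from compound 1 to compound 3 (0.81 log units; beyond the scatter) and is the first change that can be read in one place. The substituent at this position therefore moves the read-out beyond the scatter, which the comparison of compound 1 with compound 2 could not show, since those two differ elsewhere in the molecule. No measurement in hand accounts for this step, and its origin remains unassigned.

Still open, going by these compounds, is how other groups at this position would compare with ethyl and chloro, such as a longer chain like butyl, an amine or a carboxylic acid. Also open, on these data alone, is whether the same exchange would give a step of similar size on the biaryl arrangement of compound 2.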